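The compounds below may be only part of what the source reports. "The series", "measured", "known", "first", "only" and "open" are said of these compounds alone.

Compound 1 `Cc1c(Cc2ccccc2)c(=O)oc2cc(OCC(O)CNCc3ccccc3)ccc12` and compound 2 `Cc1c(Cc2ccccc2)c(=O)oc2cc(OCC(O)CNCCCCCCO)ccc12` share one core and differ only in the group on the amine nitrogen. In an ADME assay on A549 cells (Homo sapiens) for cytotoxicity, read by CellTiter-Glo (a lower number here means that less compound is tolerated, a higher number that more compound is tolerated), compound 1 reaches only the assay limit > 100000 nM. Within the data shown here, compound 2 gives 40300 nM, the only plain number so far. Replacing phenyl by 5-hydroxypentyl produced an at least 2.4-fold lower number from compound 1 to compound 2 (0.39 log units; beyond the scatter). Compound 3 `Cc1ccc2nc(NCC(O)COc3ccc4c(C)c(Cc5ccccc5)c(=O)oc4c3)sc2c1` carries 6-methyl-1,3-benzothiazol-2-yl in place of 6-hydroxyhexyl on an amine nitrogen. This swap runs the other way, from a hydroxyalkyl chain back to an aromatic group, so a rise toward the limit is expected, roughly a 2.0-fold higher number from compound 2 to compound 3 (0.30 log units; within the scatter). Compound 3 is therefore estimated near 80000 nM, between 30000 nM and 200000 nM.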

Compound 3, half-maximal cytotoxic concentration: > 100000 nM
Compound 3: only a limit was reported; the forecaster's own chance of this, stated with the estimate: 50%; middle value at least 1.2-fold (0.09 log units) from the limit.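

Putting 6-methyl-1,3-benzothiazol-2-yl in place of 6-hydroxyhexyl on the amine nitrogen gives an at least 2.4-fold higher number from compound 2 to compound 3 (0.39 log units; beyond the scatter) in this assay. A group with two aromatic rings bound directly to that nitrogen therefore behaves like the benzyl group of compound 1, and among the compounds shown only the hydroxyalkyl chain gives a plain number. The step from compound 1 to compound 3 cannot be read, as both values are limits: the limit of > 100000 nM in this assay, at which 2 of the 3 values shown sit.

Still open, going by these compounds, is what the hydroxyl at the chain end contributes, which a plain hexyl group on the same nitrogen would test. On these data alone, the true values of compound 1 and compound 3 also remain unknown.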